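This account rests on a few compounds, and the source may have more. Where it says the series, first, only, none or still open, it means among the compounds named here.

Compound 1 `O=C1C=C(NC2CCCCC2)C(=O)c2c1nc1n2[C@H]2OC[C@@H](O)[C@H]2OC1`: > 16000 nM (a limit)
Compound 2 `Cc1ccc(NC2=CC(=O)c3nc4n(c3C2=O)[C@H]2OC[C@@H](O)[C@H]2OC4)cc1C`: 2690 nM
Compound 3 `O=C1C=C(N2CCCCC2)C(=O)c2c1nc1n2[C@H]2OC[C@@H](O)[C@H]2OC1`: not yet measured

Among the compounds with values here, in a functional assay on HeLa cells (Homo sapiens) for inhibition, read by sulforhodamine B assay (a lower number here means a stronger inhibitor, a higher number a weaker inhibitor), compound 2 gives 2690 nM as the only actual number so far. Compound 1 gives > 16000 nM and this is a limit of the assay, not a number.

The change now in question is piperidin-1-yl in place of (3,4-dimethylphenyl)amino on a double-bonded ring carbon. Within the data shown here, only one measured step bears on it: an at least 5.9-fold lower number from compound 1 to compound 2 (0.77 log units; beyond the scatter), where 3,4-dimethylphenyl replaced cyclohexyl on an amine nitrogen. Among the measured compounds shown here, no measured compound carries piperidin-1-yl, so this comparison is only partial.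

For the measured compounds named here, a higher number is expected for compound 3 because an at least 5.9-fold lower number from compound 1 to compound 2 (0.77 log units; beyond the scatter) is the only measured exchange of an aromatic ring for a non-aromatic one. The change to compound 3 runs in the opposite direction, so a step of similar size, beyond the scatter, is expected in this assay. The estimated step is a 5.2-fold higher number from compound 2 to compound 3 (0.72 log units; beyond the scatter) and the assay may report only a limit. For compound 3 the estimated value is 14000 nM, with an expected range of 5000 nM to 40000 nM.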

Compound 3, half-maximal inhibitory concentration: > 16000 nM
Compound 3: only a limit was reported; the forecaster's own chance of this, stated with the estimate: 50%; middle value at least 1.1-fold (0.05 log units) away from the limit.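

In this assay, the position on the double-bonded ring carbon now has a second comparison: an at least 5.9-fold higher number from compound 2 to compound 3 (0.77 log units; beyond the scatter), and the value of compound 3 is a limit, not a number. Across the three compounds, only the one with an aromatic ring in this group, compound 2, gives a number, and neither compound 1 nor compound 3 goes against this, although the pattern rests on a single aromatic example. Compound 1 keeps the hydrogen-bond donor on its cyclohexylamino group and compound 3 has none on its piperidin-1-yl group, yet the step between them cannot be read, and the two non-aromatic groups cannot be ranked: the limit of > 16000 nM in this assay, at which 2 of the 3 values shown sit.

Still open, going by these compounds, is whether the aromatic ring alone accounts for the number of compound 2 or the two methyl groups of its (3,4-dimethylphenyl)amino group also contribute, which a plain phenylamino group would separate. Also open, on these data alone, is whether an aromatic ring set further from the nitrogen, as in a benzylamino group, or a ring with a second hetero atom, as in morpholin-4-yl, would give a number rather than a limit.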